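The source may report more compounds than this note shows. Statements on the series, on what has been measured and on what is new or still open speak of the compounds shown alone.

Compound 3 `O=C(O)c1csc([C@H]2CC[C@@H]3[C@@H](COc4ccccc4F)[C@H](O)C[C@@H]3O2)n1` gives 23 nM in a functional assay on CHO cells for agonist activity at prostaglandin E2 receptor EP2 subtype (Homo sapiens), read by HTRF and cAMP accumulation, with a stated time of 30 min; a lower number here means that less compound is needed, a higher number that more compound is needed for the effect. That is the largest of the three numbers at hand, although compound 2 `O=C(O)c1csc([C@H]2CC[C@@H]3[C@@H](COc4ccc(OC(F)(F)F)cc4)[C@H](O)C[C@@H]3O2)n1` at 14 nM and compound 1 `O=C(O)c1csc([C@H]2CC[C@@H]3[C@@H](COc4ccc(C(F)(F)F)cc4)[C@H](O)C[C@@H]3O2)n1` at 13 nM both sit within the usual scatter of it. Compound 4 `Cc1ccc(OC[C@@H]2[C@H]3CC[C@H](c4nc(C(=O)O)cs4)O[C@H]3C[C@H]2O)cc1` differs from compound 3 by 4-methylphenyl in place of 2-fluorophenyl on an oxygen on a saturated carbon. Within the data shown here, the one earlier step that also exchanged the aromatic group on that oxygen, a 1.8-fold higher number from compound 1 to compound 3 (0.25 log units; within the scatter), stayed within the scatter, and a 1.1-fold higher number from compound 1 to compound 2 (0.03 log units; within the scatter), a change on that same aromatic group, did likewise. Compound 4 is therefore expected to show no shift beyond the scatter, an estimated step of a 1.2-fold lower number from compound 3 to compound 4 (0.06 log units; within the scatter). For compound 4 the expected value in this assay is 20 nM, likely between 9 nM and 45 nM.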

Compound 4, half-maximal effective concentration: 27 nM
Compound 4: middle estimate off by 1.4-fold (0.13 log units), on the low side, and the stated range covers the measured number.
By their numbers in this assay, from the lowest: compounds 1, 2, 3 and 4 (each within the scatter of the next, the first and the last beyond it).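

On the oxygen of the shared core, 4-methylphenyl in place of 2-fluorophenyl stays within the scatter (a 1.2-fold higher number from compound 3 to compound 4 (0.07 log units; within the scatter)), and so does methyl in place of trifluoromethoxy (a 1.9-fold higher number from compound 2 to compound 4 (0.29 log units; within the scatter)). Methyl in place of trifluoromethyl is the first step on this aromatic group to pass the scatter, though only modestly (a 2.1-fold higher number from compound 1 to compound 4 (0.32 log units; beyond the scatter)). No measurement here accounts for that step.

Going by these compounds, whether 2-methylphenyl or 4-fluorophenyl would tell the group's identity apart from its place on the ring stays open. So does the outcome for a phenyl ring carrying an amine.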